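Moving a ring nitrogen on a fused heteroaryl ether

This account rests on a few compounds, and the source may have more. Where it says the series, first, only, none or still open, it means among the compounds named here.

Of the compounds shown here, three sharing one core have been measured in an in vitro assay on Sf9 cells for inhibition of leukotriene A-4 hydrolase (Homo sapiens), read by immunoassay, with stated times of 10 min and 30 min; a lower number here means a stronger inhibitor, a higher number a weaker inhibitor. Compound 1 `c1cnc2nc(Oc3ccc4oc(CN5CCCCC5)cc4c3)sc2c1` gives 66 nM, compound 2 `O=C(O)C1CCN(Cc2coc3cc(Oc4nc5ncccc5s4)ccc23)CC1` gives 8.3 nM, and compound 3 `CC(=O)N1CC2CC1CN2Cc1cc2ccc(Oc3nc4ncccc4s3)cc2o1` gives 62 nM. Compound 3 sits at the second highest of the three numbers; its value and that of compound 1 lie within the scatter of each other, while compound 2 stands apart with a clearly lower number, beyond the scatter. Compound 4 `CC(=O)N1CC2CC1CN2Cc1cc2ccc(Oc3nc4cccnc4s3)cc2o1` has not yet been measured in this assay. It differs from compound 3 in this way: a group of 9 heavy atoms (6 carbon, 2 nitrogen, 1 sulfur; one five-membered aromatic ring with 2 hetero atoms, one six-membered aromatic ring with 1 hetero atom) in place of a group of 9 heavy atoms (6 carbon, 2 nitrogen, 1 sulfur; one five-membered aromatic ring with 2 hetero atoms, one six-membered aromatic ring with 1 hetero atom), on an oxygen on an aromatic ring. Nothing measured here shows what such a rearrangement does, so the change is expected to leave compound 4 near compound 3, with the step of a 1.5-fold higher number from compound 3 to compound 4 (0.16 log units; within the scatter) probably not beyond the scatter. The estimate for compound 4 is 90 nM, within a range from 30 nM to 300 nM.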

Compound 4, half-maximal inhibitory concentration: 2130 nM
Estimate against measurement, compound 4: 24-fold (1.37 log units) below; measured number outside the range, above it.
By their numbers in this assay, from the lowest: compound 2; then compounds 3 and 1 (each within the scatter of the next); then compound 4.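

Compound 3 and compound 4 have the same atoms joined differently, and that rearrangement of the group on the oxygen gives a 34-fold higher number from compound 3 to compound 4 (1.54 log units; beyond the scatter). For the compounds shown here, compound 1, compound 2 and compound 3 all carry the same group there, so only this pair shows that the arrangement within it, and not just its atom count, can change the number strongly. Nothing available explains this difference.

The compounds shown leave open whether the same rearrangement would matter as much with the other side chains of compound 1 and compound 2. They also leave open what a benzene ring would do in place of the six-membered ring holding the hetero atom.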